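Saturating the allyl chain on a shared core

The source may hold more compounds than are shown below. What is called first, only, known or untested is meant among the compounds shown, and "the series" means these compounds.

Compound 1, `C=CCn1c(=O)n(CCCC)c2nc(N)nc(O)c21`: 77%
Compound 2, `C=CCn1c(=O)n(C2C=CC(CO)O2)c2nc(N)nc(O)c21`: 45%
Compound 3, `C=CCn1c(=O)n(Cc2ccccc2)c2nc(N)nc(O)c21`: 25%

In a functional assay on the whole organism (B cells) with Mus musculus as the target (on this read-out lower numbers stand for smaller maximal responses and higher numbers for larger maximal responses), compound 2 stands second highest of the three numbers, between the other two. The measured steps are a number 32 percentage points lower from compound 1 to compound 2 (beyond the scatter), a number 20 percentage points lower from compound 2 to compound 3 (beyond the scatter) and a number 52 percentage points lower from compound 1 to compound 3 (beyond the scatter), each beyond the scatter, and each of them exchanges the group on the other aromatic nitrogen of the shared core.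

Compound 4, `CCCn1c(=O)n(C2C=CC(CO)O2)c2nc(N)nc(O)c21`, differs from compound 2 by ethyl in place of vinyl on a saturated chain carbon bound to an aromatic nitrogen. Among the compounds with values here, none of the measured steps touches the allyl chain, so no measured step bears on this change, and the data give no direction for it. Compound 4 is therefore expected to show no step beyond the scatter, no change at the digits printed from compound 2 to compound 4 (within the scatter). The estimate for compound 4 in this assay is 45%, within 30% to 60%.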

Compound 4, largest response reached (reported as maximal response), in percent of the reference or control that the assay uses: 118%
Compound 4: middle estimate off by 73 percentage points, on the low side, and the stated range ends below it.
By their numbers in this assay, from the lowest: compound 3; then compound 2; then compound 1; then compound 4.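

In this assay the allyl chain proves to be a position that counts: ethyl in place of vinyl gives a number 73 percentage points higher from compound 2 to compound 4 (beyond the scatter), the only step shown at this chain. The change keeps the count of heavy atoms in the group and removes one double bond outside aromatic rings. Nothing available here accounts for the size of this step.

From the compounds shown here alone, whether propyl has the same effect alongside the butyl of compound 1 or the benzyl of compound 3 remains open. So does the outcome with a longer chain, such as pentyl, or a terminal amine at this position.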